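Imidazole in place of hydroxypiperidine on the chain

The source may hold more compounds than are shown below. What is called first, only, known or untested is meant among the compounds shown, and "the series" means these compounds.

Compound 3 `O=C1c2c[n+]([O-])c3ccccc3c2C(=O)c2c1c1ccccc1n2CCCN1CCC(O)CC1` stands lowest of the two numbers in hand: in a functional assay on SH-SY5Y cells (Homo sapiens) for cytotoxicity, read by MTT assay, with a stated time of 72 h (on this read-out lower numbers stand for stronger inhibition and higher numbers for weaker inhibition), compound 3 gives 130 nM. Compound 1 `CN1CCN(CCCCCn2c3c(c4ccccc42)C(=O)c2c[n+]([O-])c4ccccc4c2C3=O)CC1` gives 830 nM in this assay, with a 6.4-fold lower number from compound 1 to compound 3 (0.81 log units; beyond the scatter). Compound 2 `O=C1c2c[n+]([O-])c3ccccc3c2C(=O)c2c1c1ccccc1n2Cc1cn(C[C@@H](O)CO)nn1` returns only a limit in this assay, > 500 nM, as noted in the limit of > 500 nM in this assay, at which 1 of the 3 values shown sits. The step of an at least 3.8-fold lower number from compound 2 to compound 3 (0.58 log units; beyond the scatter) is therefore readable only in part.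

Compound 4 `O=C1c2c[n+]([O-])c3ccccc3c2C(=O)c2c1c1ccccc1n2CCCCn1ccnc1` differs from compound 3 by (1H-imidazol-1-yl)methyl in place of 4-hydroxypiperidin-1-yl on a saturated chain carbon, three bonds along the chain from an aromatic nitrogen. Within the data shown here, the change closest to it is the one from compound 2 to compound 3, where an aromatic five-membered azole gave way to a saturated ring with a hydroxyl, and the number fell at least modestly; compound 4 moves back toward an aromatic azole without the hydroxyl. A modest rise in the number is expected for compound 4 in this assay, with a 3.1-fold higher number from compound 3 to compound 4 (0.49 log units; beyond the scatter), though the limit on compound 2 leaves its size uncertain. Compound 4 is estimated at 400 nM, within 150 nM to 1200 nM.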

Compound 4, half-maximal inhibitory concentration: 130 nM
Compound 4: middle estimate off by 3.1-fold (0.49 log units), on the high side; measured number below the stated range.
By their numbers in this assay, from the lowest: compounds 3 and 4 (each within the scatter of the next); then compound 1.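

At this place on the chain, three bonds along from the aromatic nitrogen, (1H-imidazol-1-yl)methyl in place of 4-hydroxypiperidin-1-yl leaves the number level in this assay, with no change at the digits printed from compound 3 to compound 4 (within the scatter), so neither a saturated ring nor a hydroxyl is needed for a number of this size in this pair. An aromatic azole on the chain is thus no penalty in itself, with an at least 3.8-fold lower number from compound 2 to compound 4 (0.58 log units; beyond the scatter), and the imidazole chain also stands apart from the methylpiperazine chain, with a 6.4-fold lower number from compound 1 to compound 4 (0.81 log units; beyond the scatter). Compound 2 stands as a limit, not a number: the limit of > 500 nM in this assay, at which 1 of the 4 values shown sits.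

Ring and chain length change together in the step to compound 4, and an imidazole on a propyl chain would separate the two. Also open, going by these compounds, is whether a morpholine or a carboxylic acid at the chain end would hold this level in this assay.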